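A Halogen-Bearing Ring Changes on a Weak Growth Inhibitor

The source may hold more compounds than are shown below. What is called first, only, known or untested is meant among the compounds shown, and "the series" means these compounds.

Of the compounds shown here, two have been tested so far in a functional assay on NPC-TW01 cells (Homo sapiens) for inhibition, read by MTT assay, with a stated time of 72 h; a lower number here means a stronger inhibitor of growth, a higher number a weaker inhibitor of growth. Compound 1 `Cc1ccc(-c2nn(-c3ccc(Br)cc3)c(/N=C/N(C)C)c2C=O)cc1` gives 6000 nM. Compound 2 `Cc1ccc(-c2nn(-c3cccc(Cl)c3)c(N)c2C=O)cc1` reads > 100000 nM, which is a limit of the assay and not a number. Compound 3 `Cc1ccc(-c2nn(-c3ccc(Br)cc3)c(N)c2C=O)cc1` has not yet been measured. It differs from compound 2 by one change on an aromatic nitrogen, with 4-bromophenyl in place of 3-chlorophenyl on an aromatic nitrogen. Compound 3 would share this 4-bromophenyl with compound 1, which gives 6000 nM but carries a different group in place of the amino group. Some gain in growth inhibition is therefore expected, though compound 1 is only a loose guide. The expected change is an at least 3.3-fold lower number from compound 2 to compound 3 (0.52 log units; beyond the scatter), and its size is uncertain with only a limit at its start. For compound 3 the estimated value is 30000 nM, with an expected range of 8000 nM to 100000 nM.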

Compound 3, concentration for 50% growth inhibition: 28200 nM
Beside the measured number, compound 3's estimate is 1.1-fold (0.03 log units) above it; the measured number falls inside the stated range.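

Replacing 3-chlorophenyl with 4-bromophenyl on the aromatic nitrogen brings the amino series into a measurable range in this assay, with an at least 3.5-fold lower number from compound 2 to compound 3 (0.54 log units; beyond the scatter). On these data alone, the true size of this step stays unknown, because its starting point is a limit of the assay and not a number: the limit of > 100000 nM in this assay, at which 1 of the 3 values shown sits. With 4-bromophenyl held in place, the group on the aromatic carbon also proves to matter, as replacing the group of compound 1 with the amino group gives a 4.7-fold higher number from compound 1 to compound 3 (0.67 log units; beyond the scatter).

The step from 3-chlorophenyl to 4-bromophenyl changes both the halogen and its place on the ring, so the compounds shown cannot separate these two changes. As far as these compounds go, a 4-chlorophenyl or 3-bromophenyl group would be needed to tell them apart, and how an acetyl group on the amino nitrogen would compare also remains open.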